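Thioether aminoindan series: propargylamine thioethers, second assay round

The source may hold more compounds than are shown below. What is called first, only, known or untested is meant among the compounds shown, and "the series" means these compounds.

Measured so far:
compound 1 `C#CCNC1CCc2c(SCCc3cccc(Cl)c3)cccc21` — "not determined" (no result reported) in an ADME assay on isolated protein for inhibition of Amine oxidase [flavin-containing] B (Homo sapiens); on this read-out higher numbers stand for weaker inhibition and lower numbers for stronger inhibition
compound 2 `C#CCNC1CCc2c(SCc3cccc(C(F)(F)F)c3)cccc21` — 7710 nM
compound 3 `C#CCNC1CCc2c(SCc3ccc(OC)cc3)cccc21` — 3960 nM

Compound 1 stands without a number: for compound 1 the entry reads "not determined" (no result reported), so its position against compound 2 and compound 3 is open. The two values that exist, from compound 2 and compound 3, lie within the usual scatter of each other, so no ordering between them is claimed.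

Compound 4 `C#CCNC1CCc2c(SCCc3ccc(OC)cc3)cccc21` differs from compound 1 by one change: 4-methoxyphenyl in place of 3-chlorophenyl on a saturated chain carbon, two bonds along the chain from a sulfur. For the measured compounds named here, since compound 1 carries no number, no step in this assay can be set down for this pair, only an expectation for compound 4 itself.

Compound 4 is expected to give about 4500 nM in this assay, likely between 1200 nM and 16000 nM, on the grounds that the closest measured relative, compound 3, gives 3960 nM.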

Compound 4, half-maximal inhibitory concentration: 4590 nM
Compound 4: middle estimate off by 1.0-fold (0.01 log units), on the low side, within the range that was stated.
By their numbers in this assay, from the lowest: compounds 3, 4 and 2 (each within the scatter of the next).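

No new step can be read for compound 4 against compound 1, and nothing at hand bears on a cause. The compounds shown leave open how 3-chlorophenyl and 4-methoxyphenyl compare on the same chain.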